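A longer ester side chain on compound 2

A few compounds are considered here, and "the series" means these few. Any claim that something is new, unique, unknown or untested is made for them only; others in the source may bear on it.

Among the measured compounds shown here, compound 1 `C=C[C@@](C)(/C=C/c1ccc(O)cc1)CC/C=C(C)/C=N/N` and compound 2 `C=C[C@@](C)(/C=C/c1ccc(O)cc1)CC/C=C(\C)C(=O)OCC` share one core and are the only compounds measured here in an ADME assay on BJ cells (Homo sapiens) for cytotoxicity, with a stated time of 72 h (on this read-out higher numbers stand for an effect only at larger amounts of compound and lower numbers for an effect already at smaller amounts), so far. Compound 1 gives > 36600 nM as a limit of the assay and not a number. Compound 2 gives > 36600 nM as a limit too, so it stands without any true number. For the measured compounds named here, the one measured step that bears on what follows is a step that the two limits leave unreadable from compound 1 to compound 2 and it offers no size to build on.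

Compound 3 `C=C[C@@](C)(/C=C/c1ccc(O)cc1)CC/C=C(C)/C=C/C(=O)OCC` is still unmeasured. Compared with compound 2 it carries this change: 2-(ethoxycarbonyl)ethenyl in place of ethoxycarbonyl on a double-bonded chain carbon bound to a double-bonded chain carbon and a saturated chain carbon with 2-(ethoxycarbonyl)ethenyl in place of ethoxycarbonyl on a double-bonded chain carbon bound to a double-bonded chain carbon and a saturated chain carbon.

A step beyond the usual scatter is not expected in this assay and no direction can be favoured because the limit of > 36600 nM in this assay, at which 2 of the 2 values shown sit, applies to compound 1 and compound 2 alike. The estimated step is a step that the limit leaves unreadable from compound 2 to compound 3 and another limit is the likeliest report. For compound 3 the expected value is 40000 nM with an estimated range from 18000 nM to 90000 nM in repeated measurements.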

Compound 3, half-maximal effective concentration: > 36600 nM
Compound 3 ended at the assay's limit (the forecaster's own chance of this, stated with the estimate: 80%); the middle value is on the limit's open side.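

No size can be read for any step among compound 1, compound 2 and compound 3, because all three stop at a limit of the assay and not at a true number: the limit of > 36600 nM in this assay, at which 3 of the 3 values shown sit. The compounds shown leave open whether any of these side chains changes the result in this assay at all, and at what concentration an effect on the cells would appear.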